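Bromo for methoxy on a shared oxazoline-ether core

This account rests on a few compounds, and the source may have more. Where it says the series, first, only, none or still open, it means among the compounds named here.

Measured so far:
compound 1 `COc1ccc(OCC2=NCCO2)cc1` gives 15%
compound 2 `Clc1ccccc1OCC1=NCCO1` gives 80%
compound 3 `Cc1cc(OCC2=NCCO2)ccc1Cl` gives 40%

Three compounds share one core and differ only in what sits on the aromatic ring. In a toxicity assay on the whole organism with Rattus norvegicus as the target, at a dose of 400 mg/kg by the oral route (a lower number here means a weaker effect, a higher number a stronger effect of the compound at the dose given), compound 1 gives 15%, the lowest of the three numbers. Its nearest neighbour is compound 3, whose number is higher by a margin beyond the scatter. Furthest away is compound 2, whose number is higher by a much wider margin, also beyond the scatter. Both of the stronger compounds carry a chloro group on the ring, whereas compound 1 carries methoxy.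

The new compound 4 `Brc1ccc(OCC2=NCCO2)cc1` has not yet been measured. Compared with compound 1 it shows this change: bromo in place of methoxy on an aromatic carbon. Among the compounds with values here, no step between measured compounds matches this change, so the expectation rests on the halogen-bearing compounds 2 and 3 both sitting higher than compound 1. A step upward beyond the scatter is expected for compound 4, as a number 25 percentage points higher from compound 1 to compound 4 (beyond the scatter). In this assay compound 4 is therefore estimated at 40%, with a plausible range from 20% to 65%.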

Compound 4, a percentage reported as activity, at one dose (the size of the read-out at that dose, not a potency): 15%
Compound 4: middle estimate off by 25 percentage points, on the high side; measured number below the stated range.
By their numbers in this assay, from the lowest: compounds 1 and 4 (each within the scatter of the next); then compound 3; then compound 2.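

In this assay, within the data shown here, putting bromo in place of methoxy on the aromatic carbon gives no change at the digits printed from compound 1 to compound 4 (within the scatter), and this is the first pair that differs in one place only. At this place, para to a group of 7 heavy atoms, the read-out at this one dose therefore cannot tell the two groups apart, even though they share no atoms and only methoxy counts a hydrogen-bond acceptor. No measured evidence here bears on why the two groups read alike.

From the compounds shown here alone, whether this sameness extends to very different groups at this place, such as an amine, a carboxylic acid or a longer alkoxy chain, stays open. The compounds shown also leave open how either group would read at another place on the ring, with the rest of the molecule unchanged.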